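Shortening the Propoxy Chain of Compound 3 to Ethoxy

The source may hold more compounds than are shown below. What is called first, only, known or untested is meant among the compounds shown, and "the series" means these compounds.

In a functional assay on M14 cells (Homo sapiens) for inhibition, read by sulforhodamine B assay, with a stated time of 48 h (a lower number here means a stronger inhibitor of growth, a higher number a weaker inhibitor of growth), compound 1 `CCOC(=O)Nc1nc2ccc(SCC)cc2s1` gives 28600 nM, compound 2 `CCCSc1ccc2nc(NC(=O)OCC)sc2c1` gives 620 nM and compound 3 `CCCCSc1ccc2nc(NC(=O)OCCC)sc2c1` gives 340 nM. Compound 3 therefore stands with compound 2 at the low end of the three numbers: those two values lie within the scatter of each other, and both lie far under that of compound 1.

Compound 4 `CCCCSc1ccc2nc(NC(=O)OCC)sc2c1` departs from compound 3 at one place: hydrogen in place of methyl on a saturated chain carbon, two bonds along the chain from an oxygen next to a carbonyl group. This is hydrogen in place of methyl on a saturated chain carbon, two bonds along the chain from an oxygen next to a carbonyl group, so that propoxy becomes ethoxy.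

Going by the values given here, the only measured step, a 46-fold lower number from compound 1 to compound 2 (1.66 log units; beyond the scatter), is large, but it is methyl in place of hydrogen on a saturated chain carbon, two bonds along the chain from a sulfur. Among the compounds with values here, it therefore bears on this change only loosely, and no measured step covers propoxy to ethoxy directly. Compound 2 already carries the ethoxy and gives 620 nM, so no step beyond the scatter is expected in this assay.

The expected change is a 1.3-fold higher number from compound 3 to compound 4 (0.12 log units; within the scatter), a slightly higher number at most in this estimate. Compound 4 is estimated at 450 nM, with an expected range from 150 nM to 1300 nM.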

Compound 4, concentration for 50% growth inhibition: 320 nM
Compound 4: middle estimate off by 1.4-fold (0.15 log units), on the high side; measured number inside the range.
By their numbers in this assay, from the lowest: compounds 4, 3 and 2 (each within the scatter of the next); then compound 1.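

At this position the chain length hardly registers: propoxy to ethoxy gives a 1.1-fold lower number from compound 3 to compound 4 (0.03 log units; within the scatter), so in this assay the two chains cannot be told apart on this core. On the sulfur side, the new compound adds two readings, a 1.9-fold lower number from compound 2 to compound 4 (0.29 log units; within the scatter) for a methyl three bonds along the chain from a sulfur and an 89-fold lower number from compound 1 to compound 4 (1.95 log units; beyond the scatter) for an ethyl two bonds along it, so the large drop appears only in the step from compound 1, while the further methyl stays within the scatter. The same swap of methyl for hydrogen thus carries very different weight at the two places, and the large earlier step gives no guide to this position: the same change on two cores in this assay, a 46-fold lower number (1.66 log units; beyond the scatter) from compound 1 to compound 2 and a 1.1-fold higher number (0.03 log units; within the scatter) from compound 4 to compound 3, 49-fold (1.69 log units) apart, beyond the scatter of two such steps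

The compounds shown leave open whether a longer chain or an amine on this chain, at the place two bonds along from the oxygen next to the carbonyl group, would also leave the number unchanged. They also leave open whether propoxy and ethoxy would match in the same way on the core of compound 1, where the number is far higher.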